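The compounds below may be only part of what the source reports. "The series", "measured", "known", "first", "only" and "open" are said of these compounds alone.

Compound 1 `O=C(O)[C@H](CO)NC(=O)[C@H]1C[C@H](O)CN1` is the starting point of this step. In an ADME assay on Jejunum (Mus musculus, strain C57BL/6) for metabolic stability, read by HPLC, with a stated time of 12 h (on this read-out higher numbers stand for a longer-lived compound and lower numbers for a shorter-lived compound), compound 1 gives > 12 h, which is a limit of the assay rather than a number. Compound 3 `O=C(O)[C@H](CO)NC(=O)[C@H]1C[C@@H](O)CN1` likewise gives > 12 h, also a limit. Compound 2 `O=C(O)[C@H](CO)NC(=O)[C@@H]1C[C@@H](O)CN1` gives 0.29 h. The readable steps are an at least 41-fold lower number from compound 1 to compound 2 (1.61 log units; beyond the scatter) and an at least 41-fold higher number from compound 2 to compound 3 (1.61 log units; beyond the scatter), whereas the step that the two limits leave unreadable from compound 1 to compound 3 cannot be read because of the limit of > 12 h in this assay, at which 2 of the 3 values shown sit. Compound 4 `O=C(O)[C@H](CO)NC(=O)[C@@H]1C[C@H](O)CN1` differs from compound 1 in this way: the two compounds have the same atoms and bonds and differ only in configuration as drawn: 1 of 3 stereo elements differ; a stereocentre at a saturated ring carbon is drawn R in compound 1 and S in compound 4. Within the data shown here, compound 1 to compound 2 changed two stereocentres; compound 3 changed only the one drawn S in compound 1, without any readable loss, and compound 4 changes the other. A large fall is therefore expected, an at least 24-fold lower number from compound 1 to compound 4 (1.38 log units; beyond the scatter). Compound 4 is estimated at 0.5 h, between 0.15 h and 6 h.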

Compound 4, half-life: 0.35 h
The estimate for compound 4 lay 1.4-fold (0.15 log units) above the measured number; the measured number falls inside the stated range.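

In this assay, inverting only the ring carbon drawn R in compound 1 is enough to bring the fall (an at least 34-fold lower number from compound 1 to compound 4 (1.53 log units; beyond the scatter)), and the same drop appears against compound 3 (an at least 34-fold lower number from compound 3 to compound 4 (1.53 log units; beyond the scatter)). Compound 2 and compound 4 stand level (a 1.2-fold higher number from compound 2 to compound 4 (0.08 log units; within the scatter)), so with this carbon drawn S, the other ring stereocentre makes no readable difference. With this carbon drawn R, the effect of that other centre cannot be read: compound 1 and compound 3 each sit at a limit of the assay. On these data alone, whether a fluorine or a methoxy group in place of the ring hydroxyl would show the same dependence on configuration stays open.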